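Debromination of compound 2: outlook for compound 3

This account rests on a few compounds, and the source may have more. Where it says the series, first, only, none or still open, it means among the compounds named here.

Measured compounds in an assay on A549 cells for inhibition of transcription factor p65 (Homo sapiens), read by fluorescence, with a stated time of 2 h; on this read-out higher numbers stand for weaker inhibition and lower numbers for stronger inhibition:
compound 1 `COc1ccc(/C=C/C(=O)c2cccc(-c3ccc(F)cc3)c2)cc1`: > 50000 nM
compound 2 `COc1cc(/C=C/C(=O)c2ccc(N)c(-c3ccc(F)cc3)c2)cc(Br)c1O`: > 50000 nM

Compound 1 gives no number in this assay but only a limit, > 50000 nM. Compound 2 likewise returns only a limit in this assay, > 50000 nM. Among the measured compounds shown here, compound 2 thus stands at the limit of > 50000 nM in this assay, at which 2 of the 2 values shown sit, so no ranking of the two measured compounds is possible and no step between them can be given; only that both sit at the same limit can be read from the numbers.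

Compound 3 `COc1cc(/C=C/C(=O)c2ccc(N)c(-c3ccc(F)cc3)c2)ccc1O` is the next member to be run in this assay. Its difference from compound 2 is hydrogen in place of bromo on an aromatic carbon. For the measured compounds named here, with both measured compounds at the limit there is no step on which to base a direction, and no ground to expect a change beyond the scatter. For compound 3 the expected outcome is therefore again a limit rather than a number, with an estimated half-maximal inhibitory concentration of 60000 nM and a plausible range of 15000 nM to 200000 nM, the expected step being a step that the limit leaves unreadable from compound 2 to compound 3.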

Compound 3, half-maximal inhibitory concentration: 6830 nM
Estimate against measurement, compound 3: 8.8-fold (0.94 log units) above; measured number below the stated range.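

In this assay, hydrogen in place of bromo on the aromatic carbon ortho to a hydroxy group gives an at least 7.3-fold lower number from compound 2 to compound 3 (0.86 log units; beyond the scatter), so this single position can bring the series from the limit to a readable number. Compound 3, at 6830 nM, is the first compound shown with an actual value, which makes it the reference point for further changes on this ring; the earlier compounds offered none, and no other step can be read from them. The step gives only a minimum size, and its true extent remains unknown because compound 2 returns no number: the limit of > 50000 nM in this assay, at which 2 of the 3 values shown sit.

As far as these compounds go, it remains open whether the number in compound 3 depends on hydrogen specifically at this position, or whether fluoro, chloro or methyl in the same place would also give a value rather than a limit. Also open, from the compounds shown here alone, is what the hydroxy group, the methoxy group and the amine on the other ring each contribute, for instance whether a methoxy group in place of the hydroxy group would keep the number of compound 3.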